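The compounds below may be only part of what the source reports. "The series", "measured", "known", "first", "only" and "open" are said of these compounds alone.

In a functional assay on the whole organism (Tail, strain ICR) with Mus musculus as the target, in the tail flick test, with a stated time of 60 min, at a dose of 6.25 umol/kg by the oral route (on this read-out higher numbers stand for a stronger effect at the one dose given and lower numbers for a weaker effect), compound 3, `CC(C)[C@H](NC(=O)CN(c1nc(Cl)nc2[nH]cnc12)C1CC1)C(=O)OCc1ccccc1`, gives 13.9%. Compound 1, `O=C(CN(c1nc(Cl)nc2[nH]cnc12)C1CC1)NCC(=O)OCc1ccccc1`, gives 13.2% in this assay, and compound 2, `N=C(N)NCCC[C@H](NC(=O)CN(c1nc(Cl)nc2[nH]cnc12)C1CC1)C(=O)O`, gives 17.5%; compound 3 thus stands second highest of these three numbers, with its gaps to compound 1 and to compound 2 both within the scatter. Compound 4, `NCCCC[C@H](NC(=O)CN(c1nc(Cl)nc2[nH]cnc12)C1CC1)C(=O)OCc1ccccc1`, differs from compound 3 in one place: 4-aminobutyl in place of isopropyl on a saturated chain carbon bound to an amide-type nitrogen and a carbonyl carbon. Among the compounds with values here, the only measured step at the same place, a number 0.7 percentage points higher from compound 1 to compound 3 (within the scatter), lay within the scatter. Within the data shown here, no measured step brings in a 4-aminobutyl group, so the expectation rests on that one step alone, and a step of a number 1.1 percentage points higher from compound 3 to compound 4 (within the scatter) is expected, one not beyond the scatter. Compound 4 is therefore expected to give 15% in this assay, within 5% to 26%.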

Compound 4, a percentage reported as activity, at one dose (the size of the read-out at that dose, not a potency): 14.8%
Beside the measured number, compound 4's estimate is 0.2 percentage points above it; the measured number falls inside the stated range.
By their numbers in this assay, from the lowest: compounds 1, 3, 4 and 2 (each within the scatter of the next).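

In this assay, the 4-aminobutyl group gives a number 0.9 percentage points higher from compound 3 to compound 4 (within the scatter), and set against hydrogen it gives a number 1.6 percentage points higher from compound 1 to compound 4 (within the scatter). At this saturated chain carbon, then, a longer chain carrying an amine separates from neither isopropyl nor hydrogen, so hydrogen, isopropyl and 4-aminobutyl all sit within the scatter of one another. Nothing available explains this flat result. From the compounds shown here alone, whether a phenyl ring or a hydroxymethyl group on the same carbon would stay within that scatter remains open.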